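Swapping a ring for a chain on a shared amide core

A few compounds are considered here, and "the series" means these few. Any claim that something is new, unique, unknown or untested is made for them only; others in the source may bear on it.

Measured compounds:
- compound 1 `O=C(NCc1ccc(F)cc1)c1nc(Br)c2cccnc2c1NCc1ccccc1` — "not determined" (no result reported)
- compound 2 `C[C@H](Nc1c(C(=O)NCc2ccc(F)cc2)nc(Br)c2cccnc12)c1ccccc1` — "not determined" (no result reported)
- compound 3 `O=C(NCc1ccc(F)cc1)c1nc(Br)c2cccnc2c1N1CCNCC1` — 7000 nM

Three compounds share one core, and only compound 3 carries a number. In a functional assay on MCF7 cells (Homo sapiens) for cytotoxicity, read by MTT assay, with a stated time of 72 h (on this read-out lower numbers stand for stronger inhibition and higher numbers for weaker inhibition), compound 3 gives 7000 nM. In this assay compound 1 gives "not determined" (no result reported). In this assay compound 2 gives "not determined" (no result reported). Within the data shown here, nothing can therefore be said about how compound 3 compares with them; its value stands alone, with no measured step beside it to show how a change at this position shifts the read-out.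

Compound 4 `NCCCNc1c(C(=O)NCc2ccc(F)cc2)nc(Br)c2cccnc12` has not yet been measured. It differs from compound 3 in one place: (3-aminopropyl)amino in place of piperazin-1-yl on an aromatic carbon. Among the measured compounds shown here, both groups that exchange here carry two nitrogen atoms and sit at the same aromatic carbon, and no measured pair shows what such an exchange does on this core.

For the measured compounds named here, with no step to lean on, the expectation for compound 4 is drawn from compound 3 alone, and the expected step of a 1.4-fold lower number from compound 3 to compound 4 (0.15 log units; within the scatter) is a small one, within the usual scatter, in no firm direction. Compound 4 is therefore estimated to give 5000 nM in this assay, within a range from 1500 nM to 15000 nM.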

Compound 4, half-maximal inhibitory concentration: 6000 nM
Compound 4: the middle estimate sits 1.2-fold (0.08 log units) below what was measured; the range from low to high includes it.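

In this assay, among these compounds, the first readable step on this shared core is a 1.2-fold lower number from compound 3 to compound 4 (0.07 log units; within the scatter) and so, at this aromatic carbon para to a bromo group, the piperazin-1-yl ring and the open (3-aminopropyl)amino chain cannot be told apart. For this pair, then, the six-membered non-aromatic ring is not needed to keep the read-out at the level seen for compound 3, and a flexible chain that also carries two nitrogen atoms serves in its place. No separate measurement bears on why these two groups read alike.

The steps that lead to compound 1 and compound 2 cannot be read, as neither compound carries a number, so this pair alone says nothing about how groups without a second nitrogen behave at this position. Also open, on these data alone, is whether the read-out would hold for a longer chain, for a chain ending in a carboxylic acid instead of an amine, or for a morpholine ring in place of the piperazine.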